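Swapping an Amino Group for Fluorine on the Shared Core

A few compounds are considered here, and "the series" means these few. Any claim that something is new, unique, unknown or untested is made for them only; others in the source may bear on it.

Compound 3 `CC(=O)OCCOn1cnc2c(S)nc(N)nc21` is the only one of the three measured compounds that returns a number in a functional assay on CCRF-CEM cells (Homo sapiens) for inhibition; a lower number here means a stronger inhibitor, a higher number a weaker inhibitor: in this assay compound 3 gives 7500 nM. Compound 1 `CC(=O)OCCOn1cnc2c(Cl)nc(N)nc21` reaches only the limit of this assay, giving > 500000 nM. Compound 2 `Nc1nc(I)nc2c1ncn2OCCO` likewise gives only the limit, > 500000 nM. For the measured compounds named here, the one measured step, an at least 66-fold lower number from compound 1 to compound 3 (1.82 log units; beyond the scatter), is large, and it rests on (the limit of > 500000 nM in this assay, at which 2 of the 3 values shown sit).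

Compound 4 `CC(=O)OCCOn1cnc2c(S)nc(F)nc21` differs from compound 3 in one place: fluoro in place of amino on an aromatic carbon. Going by the values given here, no measured pair changes this group, so the step to compound 4 has no direct precedent, and the change from chloro to sulfanyl concerns a different group and offers no guide. The estimate therefore carries a wide range. Compound 4 is expected to give about 40000 nM in this assay, most likely within 7000 nM to 300000 nM. That estimate means a 5.3-fold higher number from compound 3 to compound 4 (0.73 log units; beyond the scatter), a weakening expected to exceed the scatter but far from certain.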

Compound 4, half-maximal inhibitory concentration: 37000 nM
Estimate against measurement, compound 4: 1.1-fold (0.03 log units) above; low and high end bracket the measured number.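

For the compounds shown here, until now, the only change followed was from chloro to sulfanyl. The position between two ring nitrogen atoms now has a reading of its own: in this assay, replacing amino with fluoro gives a 4.9-fold higher number from compound 3 to compound 4 (0.69 log units; beyond the scatter). Amino at this place is therefore not required for a measurable result, since compound 4 still gives 37000 nM, although the activity is weaker than with amino. Nothing measured here explains the size of this step.

From the compounds shown here alone, it remains open what a methylamino group or a hydroxyl group would give at this same position, and whether either would fall closer to amino or to fluoro. Going by these compounds, it is also open whether fluoro in place of amino would have a similar effect with chloro instead of sulfanyl on the shared core.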